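From acetamido to amino on the shared core

A few compounds are considered here, and "the series" means these few. Any claim that something is new, unique, unknown or untested is made for them only; others in the source may bear on it.

Of the compounds shown here, two on the shared core have been measured in a functional assay on BGC-823 cells (Homo sapiens) for inhibition, read by MTT assay, with a stated time of 72 h; a higher number here means a weaker inhibitor, a lower number a stronger inhibitor. Compound 1 (`CC(C)C(=O)Nc1cccc(C(=O)/C=C2/C(=O)Nc3ccccc32)c1`) gives 6200 nM. Among the measured compounds shown here, compound 2 (`CC(=O)Nc1cccc(C(=O)/C=C2/C(=O)Nc3ccccc32)c1`) gives 9100 nM, which lies within the scatter of the other value, so compound 2 stands level with the only other measured compound. Compound 3 (`Nc1cccc(C(=O)/C=C2/C(=O)Nc3ccccc32)c1`) has not yet been measured. The change to it places hydrogen in place of acetyl on a nitrogen on an aromatic ring. For the measured compounds named here, one measured step bears on this, a 1.5-fold higher number from compound 1 to compound 2 (0.17 log units; within the scatter), with methyl in place of isopropyl on a carbonyl carbon. It stays within the scatter, but it keeps the carbonyl, whereas the new change removes it, so it is only a loose guide. Going by the values given here, no measured compound carries the free amino group. No step beyond the scatter is therefore expected in this assay, and no direction is favoured. The expected size of the change is a 1.0-fold lower number from compound 2 to compound 3 (0.00 log units; within the scatter). The estimate for compound 3 is 9000 nM, with an expected range of 3500 nM to 23000 nM.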

Compound 3, half-maximal inhibitory concentration: 29900 nM
Estimate against measurement, compound 3: 3.3-fold (0.52 log units) below, and the stated range ends below it.
By their numbers in this assay, from the lowest: compounds 1 and 2 (each within the scatter of the next); then compound 3.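

Working note on the nitrogen on an aromatic ring: in this assay the earlier swap of methyl for isopropyl on the carbonyl carbon left the number within the scatter, whereas removing the whole acyl group does not, with hydrogen in place of acetyl giving a 3.3-fold higher number from compound 2 to compound 3 (0.52 log units; beyond the scatter) and hydrogen in place of isopropylcarbonyl giving a 4.8-fold higher number from compound 1 to compound 3 (0.68 log units; beyond the scatter). Both steps are beyond the scatter and run the same way, so among these three compounds the free amino group marks the weakest inhibitor, compound 3, while the two acylated compounds stay level with each other. Nothing available explains this loss of activity on going from acylated nitrogen to free amino group.

A methylamino group, which keeps a carbon on the nitrogen but has no carbonyl, would help separate the role of the carbonyl from that of the other acyl atoms. A longer acyl chain such as hexanoyl, or a benzoyl group, would test whether the level shared by compound 1 and compound 2 holds beyond isopropylcarbonyl.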